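Swapping a five-membered ring on the chlorophenyl arm

The compounds below may be only part of what the source reports. "The series", "measured", "known", "first", "only" and "open" are said of these compounds alone.

Compound 1 `CC(C)NCc1ccc(-c2c3ncn(CC4(O)CCN(Cc5ccc(-c6ccco6)cc5Cl)CC4)c(=O)c3nn2C)cc1`: 29.1 nM
Compound 2 `Cn1nc2c(=O)n(CC3(O)CCN(Cc4ccc(-c5ccc[nH]5)cc4Cl)CC3)cnc2c1-c1ccc(CN)cc1`: 193 nM
Compound 3 `CCCNCc1ccc(-c2c3ncn(CC4(O)CCN(Cc5ccc(-c6ccco6)cc5Cl)CC4)c(=O)c3nn2C)cc1`: 43.9 nM

In an assay on isolated protein for inhibition of ubiquitin carboxyl-terminal hydrolase 7 (Homo sapiens), with stated times of 30 min and 2 h (on this read-out higher numbers stand for weaker inhibition and lower numbers for stronger inhibition), compound 2 gives the highest of the three numbers, with compound 3 at 43.9 nM and compound 1 at 29.1 nM both lying beyond the scatter below it. Compound 4 `Cn1nc2c(=O)n(CC3(O)CCN(Cc4ccc(-c5ccsc5Cl)cc4Cl)CC3)cnc2c1-c1ccc(CN)cc1` has not yet been measured. It differs from compound 2 in one place: 2-chlorothiophen-3-yl in place of 1H-pyrrol-2-yl on an aromatic carbon. For the measured compounds named here, the only measured single-point step, a 1.5-fold higher number from compound 1 to compound 3 (0.18 log units; within the scatter), concerns the substituent on the amine nitrogen at the other end of the molecule and lies within the scatter; it says nothing about the five-membered ring attached to the chlorophenyl group. Compounds 1 and 3 carry a furyl ring there but also a different amine, so no clean comparison with compound 2 exists. Going by the values given here, with no step bearing on this change, the expectation for compound 4 in this assay is a value near that of compound 2, a step of a 1.3-fold lower number from compound 2 to compound 4 (0.11 log units; within the scatter), and the estimate is 150 nM with a range from 50 nM to 500 nM.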

Compound 4, half-maximal inhibitory concentration: 453 nM
Beside the measured number, compound 4's estimate is 3.0-fold (0.48 log units) below it, and the stated range covers the measured number.
By their numbers in this assay, from the lowest: compounds 1 and 3 (each within the scatter of the next); then compound 2; then compound 4.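

In this assay, for the compounds shown here, the ring on the chlorophenyl arm turns out to matter, with a 2.3-fold higher number from compound 2 to compound 4 (0.37 log units; beyond the scatter) when 2-chlorothiophen-3-yl replaces 1H-pyrrol-2-yl; this is the first single-place step at this position, as the earlier step concerned only the substituent on the amine nitrogen. The change alters several things at once: sulfur replaces the ring nitrogen, a chlorine is added, and the hydrogen-bond donor of the pyrrole is lost, so this one step cannot separate their contributions. No measurement available here explains the step.

From the compounds shown here alone, it remains open whether the sulfur or the chlorine matters more, a question that a plain thiophen-3-yl or a 2-methylthiophen-3-yl at this place would help to settle. Also open, going by these compounds, is how a furyl ring would compare on the aminomethyl group of compound 2, given that compounds 1 and 3 differ from it in the amine as well.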